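The source may hold more compounds than are shown below. What is called first, only, known or untested is meant among the compounds shown, and "the series" means these compounds.

Measured in a functional assay on MCF7 cells (Homo sapiens) for inhibition, read by MTT assay, with a stated time of 48 h; a lower number here means a stronger inhibitor, a higher number a weaker inhibitor:
compound 1 `COc1ccc2c(c1)C/C(=C\c1cc(-c3cc(OC)c(OC)c(OC)c3)n[nH]1)C2=O` gives 2100 nM
compound 2 `COc1cc(-c2cc(/C=C/C(=O)c3ccc(Cl)c(Cl)c3)[nH]n2)cc(OC)c1OC` gives 3200 nM
compound 3 `COc1ccc(-c2cc(/C=C/C(=O)c3ccc(N)cc3)[nH]n2)cc1OC` gives 1900 nM

Compound 2 carries the largest of the three numbers, yet its gaps to compound 1 and to compound 3 both lie inside the usual scatter, so no order among the three is established by these values.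

Compound 4 `COc1cc(-c2cc(/C=C/C(=O)c3ccc(Cl)cc3)[nH]n2)cc(OC)c1OC` differs from compound 2 by hydrogen in place of chloro on an aromatic carbon. For the measured compounds named here, no measured pair shows this change, so there is nothing to calibrate it against. The expectation is a small step in this assay, not beyond the scatter, in no firm direction. Compound 4 is therefore expected to give about 3500 nM, with a range from 1500 nM to 8000 nM. The estimated step from compound 2 to compound 4 is a 1.1-fold higher number from compound 2 to compound 4 (0.04 log units; within the scatter), expected to stay within the scatter.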

Compound 4, half-maximal inhibitory concentration: 11600 nM
Estimate against measurement, compound 4: 3.3-fold (0.52 log units) below, outside the stated range (above it).
By their numbers in this assay, from the lowest: compounds 3, 1 and 2 (each within the scatter of the next); then compound 4.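

In this assay, for the compounds shown here, the change from 3,4-dichlorophenyl to 4-chlorophenyl gives a 3.6-fold higher number from compound 2 to compound 4 (0.56 log units; beyond the scatter) as the first single-place comparison. Going by these compounds alone, the aromatic carbon ortho to a chloro group and meta to a large group is therefore not indifferent to losing its chloro, which the earlier compounds could not show. Nothing available gives a reason for this step.

Whether the step is specific to chloro stays open, since fluoro, methyl, methoxy or an amine at this position do not appear among the compounds shown. From the compounds shown here alone, whether the same change gives a similar step on the core of compound 1 or compound 3 also stays open.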